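Swapping chloro for trifluoromethyl on a second benzimidazole core

A few compounds are considered here, and "the series" means these few. Any claim that something is new, unique, unknown or untested is made for them only; others in the source may bear on it.

Compound 1 `C/C(=N\NC(N)=S)c1ccc2[nH]c(-c3ccc(Cl)cc3)nc2c1` and compound 2 `C/C(=N\NC(N)=S)c1ccc2[nH]c(-c3ccc(C(F)(F)F)cc3)nc2c1` share a core and differ only by trifluoromethyl in place of chloro on an aromatic carbon. In an ADME assay on MDBK cells (Bos taurus) for cytotoxicity, read by MTT assay, with a stated time of 96 h (a higher number here means that more compound is tolerated, a lower number that less compound is tolerated), compound 1 gives only a limit of the assay, > 100000 nM. Compound 2, in this assay, gives 5000 nM. That makes an at least 20-fold lower number from compound 1 to compound 2 (1.30 log units; beyond the scatter); the size of this step is only partly known, since compound 1 sits at the limit of > 100000 nM in this assay, at which 2 of the 3 values shown sit.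

Compound 3 `CC(=O)c1ccc2c(c1)nc(-c1ccc(Cl)cc1)n2C1CCCCC1` carries a different core; how the two cores differ is not broken down here. In this assay compound 3 also gives only a limit, > 100000 nM. Compound 4 `CC(=O)c1ccc2c(c1)nc(-c1ccc(C(F)(F)F)cc1)n2C1CCCCC1` is compound 3 with trifluoromethyl in place of chloro on an aromatic carbon, the same change as from compound 1 to compound 2.

Compound 4 is therefore expected to show an at least 10-fold lower number from compound 3 to compound 4 (1.00 log units; beyond the scatter), resting on an at least 20-fold lower number from compound 1 to compound 2 (1.30 log units; beyond the scatter), although the starting limit leaves the true size open. Compound 4 is estimated at 10000 nM, between 2000 nM and 100000 nM.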

Compound 4, half-maximal cytotoxic concentration: 52000 nM
Beside the measured number, compound 4's estimate is 5.2-fold (0.72 log units) below it; low and high end bracket the measured number.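

In this assay, trifluoromethyl in place of chloro again goes with a lower number on the second core, giving an at least 1.9-fold lower number from compound 3 to compound 4 (0.28 log units; that floor lies within the scatter), so the direction recurs, although this floor alone does not carry the step beyond the scatter. The sizes of the two steps cannot be set against each other: the same change on two cores in this assay, an at least 20-fold lower number (1.30 log units; beyond the scatter) from compound 1 to compound 2 and an at least 1.9-fold lower number (0.28 log units; that floor lies within the scatter) from compound 3 to compound 4; the limit leaves it open whether they differ. Each step starts from a limit of the assay and not from a number, so neither has a known true size: the limit of > 100000 nM in this assay, at which 2 of the 4 values shown sit.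

The compounds shown leave open how either core responds when a nitrile or an amine stands on that aromatic carbon instead. They also leave open whether the same change behaves alike on any further core.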